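A few compounds are considered here, and "the series" means these few. Any claim that something is new, unique, unknown or untested is made for them only; others in the source may bear on it.

Compound 1 `COc1ccc(C2CC(c3ccc(O)cc3)=NN2C(=O)c2cccnc2)cc1OC`: 53600 nM
Compound 2 `CCCc1ccc(C2CC(c3ccc(O)cc3)=NN2C(=O)c2cccnc2)cc1`: 41600 nM
Compound 3 `COc1ccc(OC)c(C2CC(c3ccc(O)cc3)=NN2C(=O)c2cccnc2)c1`: not yet measured

In an ADME assay on HepG2 cells (Homo sapiens) for cytotoxicity, read by MTT assay, with a stated time of 7 days (a lower number here means a stronger inhibitor, a higher number a weaker inhibitor), compound 2 gives 41600 nM, and compound 1 gives 53600 nM; the two numbers sit within the scatter of each other, so neither stands apart. Going by the values given here, the only measured step, a 1.3-fold lower number from compound 1 to compound 2 (0.11 log units; within the scatter), also swaps the aryl group on the same saturated ring carbon that changes here, (2,5-dimethoxyphenyl in place of 4-propylphenyl on a saturated ring carbon), and it moved nothing beyond the scatter. Compound 3 is therefore expected to land close to compound 2, with a 1.2-fold higher number from compound 2 to compound 3 (0.06 log units; within the scatter). The estimate for compound 3 is 48000 nM, expected between 24000 nM and 96000 nM.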

Compound 3, half-maximal inhibitory concentration: 56800 nM
The estimate for compound 3 lay 1.2-fold (0.07 log units) below the measured number; measured number inside the range.
By their numbers in this assay, from the lowest: compounds 2, 1 and 3 (each within the scatter of the next).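

In this assay, the aryl group on this saturated ring carbon can go from 4-propylphenyl to 2,5-dimethoxyphenyl, with its two hydrogen-bond acceptors (a 1.4-fold higher number from compound 2 to compound 3 (0.14 log units; within the scatter)), without any change beyond the scatter. Moving the two methoxy groups, from 3,4-dimethoxyphenyl to 2,5-dimethoxyphenyl (a 1.1-fold higher number from compound 1 to compound 3 (0.03 log units; within the scatter)), also stays within the scatter, so these three aryl groups read alike here. No outside evidence bears on this result. On these data alone, whether an amine or a carboxylic acid on this aryl ring would shift the number remains open. So does the effect of replacing the 4-hydroxyphenyl group or the (pyridin-3-yl)carbonyl group.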